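The source may report more compounds than this note shows. Statements on the series, on what has been measured and on what is new or still open speak of the compounds shown alone.

In a functional assay on HEL cells (Homo sapiens) (a higher number here means that more compound is tolerated, a lower number that less compound is tolerated), compound 2 `COC(=O)CNC1=CS(=O)(=O)O[C@@]12[C@@H](CO[Si](C)(C)C(C)(C)C)O[C@@H](n1cc(C)c(=O)n(C)c1=O)[C@@H]2O[Si](C)(C)C(C)(C)C` gives 160000 nM, within the scatter of compound 1 `Cc1cn([C@@H]2O[C@H](CO[Si](C)(C)C(C)(C)C)[C@@]3(OS(=O)(=O)C=C3NCC(=O)O)[C@H]2O[Si](C)(C)C(C)(C)C)c(=O)n(C)c1=O` at 136000 nM, while compound 3 `COC(=O)CC(=O)NC1=CS(=O)(=O)O[C@@]12[C@@H](CO[Si](C)(C)C(C)(C)C)O[C@@H](n1cc(C)c(=O)n(C)c1=O)[C@@H]2O[Si](C)(C)C(C)(C)C` lies lower at 29000 nM. Compound 4 `Cc1cn([C@@H]2O[C@H](CO[Si](C)(C)C(C)(C)C)[C@@]3(OS(=O)(=O)C=C3NC(=O)c3ccccc3)[C@H]2O[Si](C)(C)C(C)(C)C)c(=O)n(C)c1=O` carries benzoyl in place of (methoxycarbonyl)methyl on an amine nitrogen. The nearest guide is a 5.5-fold lower number from compound 2 to compound 3 (0.74 log units; beyond the scatter), where ((methoxycarbonyl)methyl)carbonyl likewise replaces (methoxycarbonyl)methyl on that nitrogen. The parallel a 4.7-fold lower number from compound 1 to compound 3 (0.67 log units; beyond the scatter) is of similar size, whereas a 1.2-fold higher number from compound 1 to compound 2 (0.07 log units; within the scatter) shows that the ester and acid forms do not separate. A modest downward step of similar size is therefore expected, an estimated 4.6-fold lower number from compound 2 to compound 4 (0.66 log units; beyond the scatter). The expected value for compound 4 is 35000 nM, with an estimated range from 12000 nM to 100000 nM.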

Compound 4, half-maximal cytotoxic concentration: 9700 nM
Beside the measured number, compound 4's estimate is 3.6-fold (0.56 log units) above it; measured number outside the range, below it.
By their numbers in this assay, from the lowest: compound 4; then compound 3; then compounds 1 and 2 (each within the scatter of the next).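

In this assay benzoyl on the amine nitrogen brings a large fall (a 16-fold lower number from compound 2 to compound 4 (1.22 log units; beyond the scatter)), and the fall is also large from the acid (a 14-fold lower number from compound 1 to compound 4 (1.15 log units; beyond the scatter)). The carbonyl on that nitrogen does not settle the number alone, since phenyl on the carbonyl carbon also separates from (methoxycarbonyl)methyl (a 3.0-fold lower number from compound 3 to compound 4 (0.48 log units; beyond the scatter)). Nothing given here accounts for this order. Going by these compounds, whether the number follows the aromatic ring or its attachment through a carbonyl stays open; benzyl or acetyl on that nitrogen would separate the two.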